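Hydroxy for Hydrogen on the Third Ring of Compound 3

The source may hold more compounds than are shown below. What is called first, only, known or untested is meant among the compounds shown, and "the series" means these compounds.

Of the compounds shown here, three of one shared core have been measured in a functional assay on HeLa cells (Homo sapiens) for inhibition, read by trypan blue exclusion, with a stated time of 72 h; a higher number here means a weaker inhibitor of growth, a lower number a stronger inhibitor of growth. Compound 1 `CC/C(=C(/c1ccc(NC(=O)C(C)C)cc1)c1ccc(OC)cc1)c1ccccc1` reaches only the limit of this assay, > 30000 nM; that limit is a limit and not a number (the limit of > 30000 nM in this assay, at which 1 of the 3 values shown sits). Compound 2 `CC/C(=C(/c1ccccc1)c1ccc(NC(=O)C(C)C)cc1)c1ccccc1` gives 28100 nM in this assay, and compound 3 `CC/C(=C(\c1ccc(NC(=O)C(C)C)cc1)c1ccc(OC)cc1)c1ccccc1` gives 10100 nM. Compound 3 therefore holds the lowest of the two numbers shown, with compound 2 nearest to it. The step from compound 1 to compound 3 is an at least 2.9-fold lower number from compound 1 to compound 3 (0.47 log units; beyond the scatter), and the two differ only in the configuration as drawn (the fact that compounds 1 and 3 differ only in the configuration as drawn). The step from compound 2 to compound 3 is a 2.8-fold lower number from compound 2 to compound 3 (0.44 log units; beyond the scatter), a methoxy in place of hydrogen on an aromatic carbon.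

Compound 4 `CC/C(=C(\c1ccc(NC(=O)C(C)C)cc1)c1ccc(OC)cc1)c1ccc(O)cc1` is not yet measured. It differs from compound 3 by hydroxy in place of hydrogen on an aromatic carbon. Among the measured compounds shown here, no measured step introduces a hydroxy, so only the step of a 2.8-fold lower number from compound 2 to compound 3 (0.44 log units; beyond the scatter), another small oxygen group entering an aromatic carbon, bears on it, and that step was modest. An expected step of about a 2.5-fold lower number from compound 3 to compound 4 (0.40 log units; beyond the scatter) in this assay follows for compound 4, a modest lowering, though a step within the scatter cannot be ruled out. Compound 4 is thus estimated at 4000 nM in this assay, in the range 1500 nM to 15000 nM.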

Compound 4, concentration for 50% growth inhibition: 3700 nM
Compound 4: the middle estimate sits 1.1-fold (0.03 log units) above what was measured, within the range that was stated.
By their numbers in this assay, from the lowest: compound 4; then compound 3; then compound 2. At a limit, above all of these: compound 1.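

In this assay, the change from phenyl to 4-hydroxyphenyl gives a 2.7-fold lower number from compound 3 to compound 4 (0.44 log units; beyond the scatter), so the ring that stayed unsubstituted in compounds 1, 2 and 3 is now shown to be a place where a single substituent changes the read-out beyond the scatter. Among the compounds shown here, this is the first measured step that brings in a hydroxy, and the first on this ring; like the methoxy step on another ring, it is modest in size. Nothing measured in this set accounts for the size of the step.

What the compounds shown leave open is whether the number falls further, holds or rises with a different group at this same place, such as a methoxy, an amine or a carboxylic acid, since hydroxy is the only substituent shown on this ring. Also open, going by these compounds, is whether a hydroxy here would have any comparable effect in the double-bond configuration of compound 1, whose > 30000 nM is a limit and not a number.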